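This account rests on a few compounds, and the source may have more. Where it says the series, first, only, none or still open, it means among the compounds named here.

The measured compounds:

Compound 1, `O=C1/C(=C/c2cccnc2)CN(S(=O)(=O)c2ccc([N+](=O)[O-])cc2)C/C1=C\c1ccccc1F`, in an ADME assay on L02 cells (Homo sapiens) for cytotoxicity, read by MTT assay, with a stated time of 24 h (on this read-out higher numbers stand for weaker inhibition and lower numbers for stronger inhibition), compound 1 gives > 20000 nM.
Compound 2, `O=C1/C(=C/c2cccnc2)CN(S(=O)(=O)c2ccc(C(F)(F)F)cc2)C/C1=C\c1ccccc1F`, compound 2 gives 11300 nM.
Compound 3, `O=C1/C(=C/c2ccncc2)CN(S(=O)(=O)c2ccc([N+](=O)[O-])cc2)C/C1=C\c1ccccc1C(F)(F)F`, compound 3 gives 18600 nM.

The value of compound 1 is a limit of this assay, not a number (the limit of > 20000 nM in this assay, at which 1 of the 3 values shown sits). Compound 1 and compound 2 differ in one place: trifluoromethyl in place of nitro on an aromatic carbon. That change gave an at least 1.7-fold lower number from compound 1 to compound 2 (0.24 log units; that floor lies within the scatter). The cores of compound 1 and compound 3 differ in more than one place, and the difference between the two cores is not broken down here.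

Compound 4, `O=C1/C(=C/c2ccncc2)CN(S(=O)(=O)c2ccc(C(F)(F)F)cc2)C/C1=C\c1ccccc1C(F)(F)F`, has not yet been measured. It differs from compound 3 in one place: trifluoromethyl in place of nitro on an aromatic carbon. The place is described in the same words as for the change from compound 1 to compound 2, so it is the same change on a different core.

The step from compound 3 to compound 4 is expected to be a 1.9-fold lower number from compound 3 to compound 4 (0.27 log units; within the scatter), resting on the change from compound 1 to compound 2, which gave an at least 1.7-fold lower number from compound 1 to compound 2 (0.24 log units; that floor lies within the scatter), and on the value of compound 3, 18600 nM. Compound 4 is estimated at 10000 nM in this assay, in the range 4500 nM to 22000 nM.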

Compound 4, half-maximal inhibitory concentration: 13800 nM
Estimate against measurement, compound 4: 1.4-fold (0.14 log units) below; the measured number falls inside the stated range.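

Replacing nitro with trifluoromethyl on the core of compound 3 gave a 1.3-fold lower number from compound 3 to compound 4 (0.13 log units; within the scatter) in this assay, so on this core the change cannot be told apart from repeat-to-repeat variation. Set beside the same change on the core of compound 1, this result gives no sign that the two cores respond differently, but it also does not show that they respond alike: the same change on two cores in this assay, an at least 1.7-fold lower number (0.24 log units; that floor lies within the scatter) from compound 1 to compound 2 and a 1.3-fold lower number (0.13 log units; within the scatter) from compound 3 to compound 4; the limit leaves it open whether they differ. Going by these compounds, compound 1 gives > 20000 nM, which is a limit of the assay and not a number, so the true size of the earlier step remains unknown.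

The compounds shown leave open what an amine or a carboxylic acid would do on the same aromatic carbon, where only nitro and trifluoromethyl appear here. They also leave open whether the change would carry over to a third core, since it is seen on only two.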